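The source may hold more compounds than are shown below. What is called first, only, known or untested is meant among the compounds shown, and "the series" means these compounds.

Three compounds have been measured in a functional assay on K562 cells (Homo sapiens) for antiproliferative activity, with a stated time of 72 h; on this read-out higher numbers stand for weaker inhibition and lower numbers for stronger inhibition:

compound 1, `OC[C@H]1O[C@@H](n2cnc3c(NCc4ccccc4F)ncnc32)[C@H](O)[C@@H]1O`, gives 33200 nM.
compound 2, `OC[C@H]1O[C@@H](n2cnc3c(NCc4ccc(Br)cc4)ncnc32)[C@H](O)[C@@H]1O`, gives 68200 nM.
compound 3, `COc1cc(CNc2ncnc3c2ncn3[C@@H]2O[C@H](CO)[C@@H](O)[C@H]2O)cc(OC)c1`, gives only a limit of the assay, > 166000 nM.

Compound 3 therefore stands at the weak end of what is shown, sitting at the limit of > 166000 nM in this assay, at which 1 of the 3 values shown sits, so its number is not known exactly. Going from compound 1 to compound 2 gave a 2.1-fold higher number from compound 1 to compound 2 (0.31 log units; beyond the scatter), and going from compound 2 to compound 3 gave an at least 2.4-fold higher number from compound 2 to compound 3 (0.38 log units; beyond the scatter).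

Compound 4, `OC[C@H]1O[C@@H](n2cnc3c(NCc4ccc(C(F)(F)F)cc4)ncnc32)[C@H](O)[C@@H]1O`, has not yet been measured. It differs from compound 3 in one place: 4-(trifluoromethyl)phenyl in place of 3,5-dimethoxyphenyl on a saturated chain carbon bound to a nitrogen on an aromatic ring. Within the data shown here, the step that bears most on this change is the one from compound 2 to compound 3, since compound 2 also carries a phenyl with a single substituent, and that step went toward weaker inhibition; the new group in compound 4 reverses the direction of that change, so a move back toward the number of compound 2 is expected. The step from compound 3 to compound 4 in this assay is thus expected to be an at least 2.0-fold lower number from compound 3 to compound 4 (0.31 log units; beyond the scatter), toward stronger inhibition. Compound 4 is estimated at 80000 nM, with a likely range from 30000 nM to 200000 nM.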

Compound 4, half-maximal inhibitory concentration: > 166000 nM
Compound 4: no number, only a limit; the forecaster's own chance of this, stated with the estimate: 30%; at least 2.0-fold (0.31 log units) between middle value and limit.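

Replacing bromo with trifluoromethyl on an aromatic carbon gives an at least 2.4-fold higher number from compound 2 to compound 4 (0.38 log units; beyond the scatter) in this assay, so carrying a single substituent on the phenyl does not by itself keep a measurable value; the identity of that substituent matters. Compared with the 2-fluorophenyl group, the new group gives an at least 5.0-fold higher number from compound 1 to compound 4 (0.69 log units; beyond the scatter). The step between compound 3 and compound 4 cannot be read, because the two compounds rest on one and the same limit, which gives no exact number for either: the limit of > 166000 nM in this assay, at which 2 of the 4 values shown sit.

From the compounds shown here alone, how far compound 4 and compound 3 lie past that limit remains unknown, so the 3,5-dimethoxyphenyl and 4-(trifluoromethyl)phenyl groups cannot be ranked against each other. Also open, going by these compounds, is how this position on the saturated chain carbon would respond to a plain phenyl, to a phenyl carrying an amine or a carboxylic acid, or to a longer chain, and whether any such group would give a stronger result than the 2-fluorophenyl group of compound 1.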